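Dimethylamino for methyl on a hydrazide-linked imine

The compounds below may be only part of what the source reports. "The series", "measured", "known", "first", "only" and "open" are said of these compounds alone.

Measured compounds:
Compound 1, `O=C(NNc1ccnc2cc(Cl)ccc12)c1ccccc1/N=C/c1ccccc1Cl`, gives 5.5.
Compound 2, `Cc1ccc(/C=N/c2ccccc2C(=O)NNc2ccnc3cc(Cl)ccc23)cc1`, gives 5.31.

Both measurements come from a physicochemical assay for lipophilicity, measured as octanol-water partition; a higher number here means a more lipophilic compound, a lower number a more polar compound. Compound 2 has the lower of the two numbers, yet the gap to compound 1 is small: the step of a number 0.19 log units lower from compound 1 to compound 2 (within the scatter) lies within the scatter, so the two compounds cannot be told apart on this reading. Among the compounds with values here, the only change between them was 4-methylphenyl in place of 2-chlorophenyl on a carbon with a double bond to nitrogen.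

Compound 3, `CN(C)c1ccc(/C=N/c2ccccc2C(=O)NNc2ccnc3cc(Cl)ccc23)cc1`, has not yet been measured. It differs from compound 2 in one place: dimethylamino in place of methyl on an aromatic carbon. Within the data shown here, no measured step covers this kind of change; the single known step concerns a different exchange on the same ring and was within the scatter, so it gives no direct guide here.

For compound 3 a modest downward step is expected in this assay, a number 0.36 log units lower from compound 2 to compound 3 (beyond the scatter), since only the shared core and the imine-bearing ring are unchanged. The estimate for compound 3 is 4.95, with a range from 4.5 to 5.4.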

Compound 3, partition coefficient: 5.03
For compound 3 the middle estimate is 0.08 log units below the measured one; low and high end bracket the measured number.
By their numbers in this assay, from the lowest: compounds 3, 2 and 1 (each within the scatter of the next, the first and the last beyond it).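

In this assay the exchange at this aromatic carbon gives a number 0.28 log units lower from compound 2 to compound 3 (within the scatter), so compound 2 and compound 3 cannot be told apart on this reading, even though dimethylamino is a larger group than methyl and brings a hydrogen-bond acceptor that methyl lacks. Within the data shown here, measured against the 2-chlorophenyl group of compound 1, the same 4-(dimethylamino)phenyl group gives a number 0.47 log units lower from compound 1 to compound 3 (beyond the scatter), the first step in this short series to pass the scatter, although it remains modest and compound 2 sits within the scatter of both neighbours. No measurement is available that would explain either step.

The compounds shown place only methyl and dimethylamino at this spot on the ring, so it remains open how a primary amine, a carboxylic acid or a longer alkyl chain there would read in this assay. The step from compound 1 also changes both the group and where it sits on the ring, and a 4-chlorophenyl group would be one way to separate those two changes.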